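The source may hold more compounds than are shown below. What is called first, only, known or untested is meant among the compounds shown, and "the series" means these compounds.

In a functional assay on the whole organism (strain Sprague-Dawley) for inhibition, with Rattus norvegicus as the target (a higher number here means that more compound is needed for the effect, a lower number that less compound is needed), compound 2 `FC(F)(F)c1ccc2cc(-c3nn[nH]n3)cnc2c1` gives 25 mg/kg. Compound 3 `Cc1ccc2cc(-c3nn[nH]n3)cnc2c1C` gives 25 mg/kg in this assay, level with compound 2 within the scatter. Compound 1 `O=C(O)c1cnc2cc(C(F)(F)F)ccc2c1` shows only a limit in this assay, > 25 mg/kg, not a number. Among the compounds with values here, the single measured step, a number no higher from compound 1 to compound 2 (the limit leaves the size open), has no readable size, since compound 1 sits at the limit of > 25 mg/kg in this assay, at which 1 of the 3 values shown sits. Compound 4 `c1ccc2ncc(-c3nn[nH]n3)cc2c1` differs from compound 2 in one place: hydrogen in place of trifluoromethyl on an aromatic carbon. The trifluoromethyl leaves and hydrogen enters. Within the data shown here, no measured step removes this group, so the expectation leans on compound 3, which lacks the trifluoromethyl yet gives 25 mg/kg in this assay. Compound 4 is therefore expected to show a step of no change at the digits printed from compound 2 to compound 4 (within the scatter), within the scatter. Compound 4 is estimated at 25 mg/kg, with a range from 12 mg/kg to 60 mg/kg.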

Compound 4, minimum effective dose: 25 mg/kg
Estimate against measurement, compound 4: no gap at the digits printed, within the range that was stated.
By their numbers in this assay, from the lowest: compounds 2, 3 and 4 (each within the scatter of the next).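

In this assay, hydrogen in place of trifluoromethyl gives no change at the digits printed from compound 2 to compound 4 (within the scatter). Within the data shown here, this is the first measured step at this position, since the earlier step changed the carboxy group instead. Here, the trifluoromethyl and a plain hydrogen are not told apart by this assay.

Going by these compounds, whether an amine or a longer chain at this position would move the number remains open. The value of compound 1 is a limit and not a number, so the step that starts from it cannot be read: the limit of > 25 mg/kg in this assay, at which 1 of the 4 values shown sits.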